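Swapping pyridazine for a trifluoromethyl pyridine

This account rests on a few compounds, and the source may have more. Where it says the series, first, only, none or still open, it means among the compounds named here.

Measured in an ADME assay on microsomes from liver (Rattus norvegicus) for metabolic stability, read by LC-MS, with a stated time of 30 min, tested at 0.1 uM; on this read-out lower numbers stand for a less stable compound and higher numbers for a more stable compound:
- Compound 1 `COc1ccc(Nc2cc3[nH]c(-c4cccc(C(F)(F)F)c4)nc3cn2)nc1`: 32%
- Compound 2 `FC(F)(F)c1cccc(-c2nc3cnc(Nc4ccncn4)cc3[nH]2)c1`: 88%
- Compound 3 `FC(F)(F)c1cccc(-c2nc3cnc(Nc4cccnn4)cc3[nH]2)c1`: 69%

Compound 3 sits in the middle of this set, below compound 2 and above compound 1. Compound 4 `FC(F)(F)c1ccc(Nc2cc3[nH]c(-c4cccc(C(F)(F)F)c4)nc3cn2)nc1`, not yet measured, keeps the shared core and changes one group on a nitrogen on an aromatic ring: 5-(trifluoromethyl)pyridin-2-yl in place of pyridazin-3-yl on a nitrogen on an aromatic ring.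

The closest guide is a number 37 percentage points higher from compound 1 to compound 3 (beyond the scatter), where pyridazin-3-yl replaced 5-methoxypyridin-2-yl. The incoming 5-(trifluoromethyl)pyridin-2-yl is also a substituted pyridin-2-yl group, so part of that gain may be lost. Among the measured compounds shown here, how much is unclear, since no measured compound carries this group. The same holds for a number 56 percentage points higher from compound 1 to compound 2 (beyond the scatter). Also, a number 19 percentage points lower from compound 2 to compound 3 (beyond the scatter) shows that a swap between pyrimidin-4-yl and pyridazin-3-yl alone moves the number in this assay.

A modest drop is therefore expected, with an estimated step of a number 14 percentage points lower from compound 3 to compound 4 (beyond the scatter). The estimate for compound 4 is 55%, with an expected range from 30% to 80%.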

Compound 4, percent of the compound remaining: 89%
Compound 4: middle estimate off by 34 percentage points, on the low side, and the stated range ends below it.
By their numbers in this assay, from the lowest: compound 1; then compound 3; then compounds 2 and 4 (each within the scatter of the next).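

In this assay, a substituted pyridin-2-yl group on this nitrogen does not by itself go with a low number, as trifluoromethyl in place of methoxy on an aromatic carbon gives a large rise (a number 57 percentage points higher from compound 1 to compound 4 (beyond the scatter)). The 5-(trifluoromethyl)pyridin-2-yl group also improves on pyridazin-3-yl (a number 20 percentage points higher from compound 3 to compound 4 (beyond the scatter)) and cannot be told apart from pyrimidin-4-yl (a number 1 percentage points higher from compound 2 to compound 4 (within the scatter)), so the group carried by the pyridin-2-yl ring can shift this number strongly. Nothing available explains these steps.

The compounds shown carry only methoxy and trifluoromethyl on this ring, so it stays open whether a nitrile, a chlorine atom or an amine there would behave like methoxy or like trifluoromethyl. The same question stands for a pyridin-2-yl group with no added group at all.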